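A few compounds are considered here, and "the series" means these few. Any claim that something is new, unique, unknown or untested is made for them only; others in the source may bear on it.

Two members of this series have been examined in a functional assay on SW-620 cells (Homo sapiens) for inhibition, read by sulforhodamine B assay, with a stated time of 48 h, tested at 10 uM; on this read-out lower numbers stand for a stronger effect and higher numbers for a weaker effect at the one concentration tested. Compound 1, with the structure `COc1cc(Cl)cc(-c2nn(-c3cccc(NC(=O)c4cccc(C(F)(F)F)c4)c3)cc2-c2ccncc2)c1`, gives 77% in this assay. Compound 2, with the structure `O=C(Nc1cccc(-n2cc(-c3ccncc3)c(-c3cc(O)cc(Cl)c3)n2)c1)c1cc(C(F)(F)F)cc(C(F)(F)F)c1`, gives 61% in this assay, which is the lowest of the two numbers; the nearest is compound 1, whose number is higher by an amount beyond the usual scatter. Compound 3, with the structure `COc1cc(Cl)cc(-c2nn(-c3cccc(NC(=O)c4cc(C(F)(F)F)cc(C(F)(F)F)c4)c3)cc2-c2ccncc2)c1`, has not yet been measured. Compound 3 differs from compound 2 by methyl in place of hydrogen on an oxygen on an aromatic ring, the hydroxy of compound 2 becoming a methoxy. Among the compounds with values here, no measured pair isolates that single change, so its effect cannot be read from the data. The step from compound 2 to compound 3 is estimated to be small, a number 3 percentage points higher from compound 2 to compound 3 (within the scatter), likely not beyond the scatter. Compound 3 is therefore expected to give about 64% in this assay, with a plausible range from 48% to 80%.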

Compound 3, a percentage reported as activity, at one concentration (the size of the read-out at that concentration, not a potency): 86.2%
For compound 3 the middle estimate is 22.2 percentage points below the measured one; measured number above the stated range.
By their numbers in this assay, from the lowest: compound 2; then compounds 1 and 3 (each within the scatter of the next).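

In this assay, methyl in place of hydrogen on an oxygen on an aromatic ring gives a number 25.2 percentage points higher from compound 2 to compound 3 (beyond the scatter) and so takes the effect at the one concentration tested from stronger to weaker. This shows that the hydroxy position responds to a single added methyl by more than the scatter, while trifluoromethyl in place of hydrogen on an aromatic carbon, with the methoxy present, gives only a number 9.2 percentage points higher from compound 1 to compound 3 (within the scatter) and no readable change. Nothing available explains either step.

From the compounds shown here alone, whether the trifluoromethyl change would also make no readable difference with the hydroxy present remains open. So does how this position would respond to an ethoxy group, or to an amine or a fluorine in place of the hydroxy.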